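A few compounds are considered here, and "the series" means these few. Any claim that something is new, unique, unknown or untested is made for them only; others in the source may bear on it.

Two compounds of the series have numbers in an assay for displacement of a labelled ligand from melanin-concentrating hormone receptor 1 (Homo sapiens), read by fluorescence; on this read-out lower numbers stand for stronger inhibition and higher numbers for weaker inhibition. Compound 1 `CC(=O)Nc1cccc(C2CCN(CCCn3c(-c4cccc(C(F)(F)F)c4)nc4ccccc43)CC2)c1` gives 30 nM. Compound 2 `COc1ccc(-c2nc3ccccc3n2CCCN2CCC(c3cccc(NC(C)=O)c3)CC2)cc1` gives 9 nM. Among the compounds with values here, the one step that can be read between them, a 3.3-fold lower number from compound 1 to compound 2 (0.52 log units; beyond the scatter), is the only step so far, and on it compound 2 holds the lowest number of the two, with compound 1 as nearest neighbour beyond the scatter.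

Compound 3 `CC(=O)Nc1cccc(C2CCN(CCCn3c(-c4ccc(Br)cc4)nc4ccccc43)CC2)c1` is the next compound in this assay. Against compound 2 the change is bromo in place of methoxy on an aromatic carbon; the group that leaves carries one hydrogen-bond acceptor, the group that enters none, and neither is part of a ring. Within the data shown here, no measured step shows this exchange, so the 1>2 step bears on it only as a general indication that the aryl substituent on this part of the core moves the number by a modest amount. The expectation for compound 3 is therefore a step of no more than modest size, likely within or just beyond the scatter, in either direction, written as a 1.3-fold higher number from compound 2 to compound 3 (0.12 log units; within the scatter). Compound 3 is estimated at 12 nM, with a range from 4 nM to 40 nM.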

Compound 3, half-maximal inhibitory concentration: 5 nM
Beside the measured number, compound 3's estimate is 2.4-fold (0.38 log units) above it; measured number inside the range.
By their numbers in this assay, from the lowest: compounds 3 and 2 (each within the scatter of the next); then compound 1.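

In this assay, the 4-bromophenyl and 4-methoxyphenyl groups are not told apart at this position: a 1.8-fold lower number from compound 2 to compound 3 (0.26 log units; within the scatter). A group para to a large group with no hydrogen-bond acceptor therefore gives a number within the scatter of one with a hydrogen-bond acceptor, so that acceptor is not required for a number of this size. The 3-(trifluoromethyl)phenyl of compound 1 now differs from two groups rather than one, with a 6.0-fold lower number from compound 1 to compound 3 (0.78 log units; beyond the scatter) joining a 3.3-fold lower number from compound 1 to compound 2 (0.52 log units; beyond the scatter), but both steps change the group and its place on the ring together, and nothing available explains the numbers.

The compounds shown leave open whether a 4-(trifluoromethyl)phenyl would read with compound 1 or with compound 2 and compound 3, which would separate the effect of the group from that of its place on the ring. Also open, going by these compounds, is whether a 4-aminophenyl or a 4-carboxyphenyl, carrying an amine or a carboxylic acid at the same place, would stay in this range.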